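The source may hold more compounds than are shown below. What is called first, only, known or untested is meant among the compounds shown, and "the series" means these compounds.

Working notes on the series. Among the compounds with values here, compound 1, `COc1cc(-c2nn(-c3cccc(NC(=O)c4ccc(Cl)c(C(F)(F)F)c4)c3)cc2-c2ccncc2)ccc1Cl`, is the weaker of the two compounds measured so far in a functional assay on MOLT-4 cells (Homo sapiens) for inhibition, read by sulforhodamine B assay, with a stated time of 48 h (a higher number here means a weaker inhibitor of growth, a lower number a stronger inhibitor of growth), where compound 1 gives 5240 nM. Within the data shown here, the only other measured member, compound 2, `O=C(Nc1cccc(-n2cc(-c3ccncc3)c(-c3ccc(Cl)c(O)c3)n2)c1)Nc1cc(C(F)(F)F)cc(C(F)(F)F)c1`, carries a urea and a different pair of aryl groups and gives 1150 nM in this assay, a difference from compound 1 that lies beyond the usual scatter; since the two structures differ in several places, no single step between them can be drawn.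

Compound 3, `COc1cc(-c2nn(-c3cccc(NC(=O)c4ccccc4)c3)cc2-c2ccncc2)ccc1Cl`, is the next point. It differs from compound 1 in one place, (phenyl in place of 4-chloro-3-(trifluoromethyl)phenyl on a carbonyl carbon). Among the measured compounds shown here, no pair already measured shows the effect of such a change, so the direction rests on expectation alone. The step from compound 1 to compound 3 is expected to be a modest loss, a 2.3-fold higher number from compound 1 to compound 3 (0.36 log units; beyond the scatter), with a move within the scatter not excluded. For compound 3 the estimate in this assay is 12000 nM, with a range of 4000 nM to 40000 nM.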

Compound 3, concentration for 50% growth inhibition: 701 nM
Compound 3: the middle estimate sits 17-fold (1.23 log units) above what was measured; the measured number lies below the stated range.
By their numbers in this assay, from the lowest: compounds 3 and 2 (each within the scatter of the next); then compound 1.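

In this assay, the step to plain phenyl on the carbonyl carbon is a gain beyond the scatter, a 7.5-fold lower number from compound 1 to compound 3 (0.87 log units; beyond the scatter), the first single-place step read in this series. It shows that this position responds to the group it carries, and that the 4-chloro-3-(trifluoromethyl)phenyl group of compound 1 is not required for growth inhibition in these cells: the unsubstituted phenyl gives the lower number. No measured property on hand explains this gain.

As far as these compounds go, it remains open whether the chlorine or the trifluoromethyl alone carries the step, as the two leave together here. Also open, from the compounds shown here alone, is how an amine or a carboxylic acid on this phenyl, or a cyclohexyl group in its place, would compare with compound 3.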